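A few compounds are considered here, and "the series" means these few. Any claim that something is new, unique, unknown or untested is made for them only; others in the source may bear on it.

Within the data shown here, in an assay on HL-60 cells for agonist activity at vitamin D3 receptor (Homo sapiens), read by microscopy, with a stated time of 96 h (a higher number here means that more compound is needed for the effect, a lower number that less compound is needed), compound 2 `CCn1c(C(=O)OC(C)CCO)ccc1C(CC)(CC)c1ccc(OCC(=O)C(C)(C)C)c(C)c1` gives 380 nM, the only plain number among the values shown here. Compound 1 `CCOC(=O)CC(C)OC(=O)c1ccc(C(CC)(CC)c2ccc(OCC(=O)C(C)(C)C)c(C)c2)n1CC` reaches only a limit of the measurement, > 50000 nM. The step of an at least 130-fold lower number from compound 1 to compound 2 (2.11 log units; beyond the scatter) is thus known only as a lower bound, because one of its two values is the limit of > 50000 nM in this assay, at which 1 of the 2 values shown sits. Compound 3 `CC[C@@H](C)[C@H](NC(=O)c1ccc(C(CC)(CC)c2ccc(OCC(=O)C(C)(C)C)c(C)c2)n1CC)C(=O)O` has not yet been measured; it differs from compound 2 by a group of 9 heavy atoms (6 carbon, 1 nitrogen, 2 oxygen; no ring) in place of a group of 6 heavy atoms (4 carbon, 2 oxygen; no ring), on a carbonyl carbon. Among the measured compounds shown here, the one measured step touched the chain beyond that carbonyl carbon, whereas this change replaces the whole group attached to it, so it bears on the new step only loosely, though it does show that alterations in this part of the molecule can move the number a long way. The step of a 2.1-fold higher number from compound 2 to compound 3 (0.32 log units; beyond the scatter) is therefore expected to be modest but uncertain in direction. Compound 3 is estimated at 800 nM, with a range from 100 nM to 10000 nM.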

Compound 3, half-maximal effective concentration: 10 nM
Estimate against measurement, compound 3: 80-fold (1.90 log units) above; measured number outside the range, below it.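

In this assay, the earlier step only altered the end of the chain beyond the carbonyl carbon, while this one replaces the whole group on that carbon with (1-carboxy-2-methylbutyl)amino and gives a 38-fold lower number from compound 2 to compound 3 (1.58 log units; beyond the scatter). So this place can lower the number a long way as well as raise it, and the full span among these compounds reaches an at least 5000-fold lower number from compound 1 to compound 3 (3.69 log units; beyond the scatter). Compound 1 stands at a limit, so that wider step is only a lower bound: the limit of > 50000 nM in this assay, at which 1 of the 3 values shown sits.

The compounds shown cannot say whether the gain comes from the nitrogen on the carbonyl carbon, the carboxy group, the side chain or the two defined stereocentres. As far as these compounds go, a (2-methylbutyl)amino group, without the carboxy, and a shorter (carboxymethyl)amino group remain open, as does the same group with its stereocentres inverted.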